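The source may report more compounds than this note shows. Statements on the series, on what has been measured and on what is new or still open speak of the compounds shown alone.

Measured compounds:
- compound 1, `COc1ccc2c(=O)c(/C=C/C(=O)Nc3cccc(Cl)c3)coc2c1`, 1100000 nM
- compound 2, `COc1ccc(NC(=O)/C=C/c2coc3cc(OC)ccc3c2=O)cc1`, 718000 nM
- compound 3, `COc1ccc2c(=O)c(/C=C/C(=O)NCc3ccc(C)cc3)coc2c1`, 257000 nM

In an ADME assay on HepG2 2.2.15 cells (Homo sapiens) for cytotoxicity, read by MTT assay, with stated times of 48 h and 9 days (a higher number here means that more compound is tolerated, a lower number that less compound is tolerated), compound 3 stands lowest of the three numbers, so it is the least tolerated of the measured set. Its nearest neighbour is compound 2 and its furthest is compound 1, both above it by margins beyond the scatter.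

Compound 4, `COc1ccc2c(=O)c(/C=C/C(=O)Nc3ccc(Cl)cc3)coc2c1`, has not yet been measured. It differs from compound 3 in one place: 4-chlorophenyl in place of 4-methylbenzyl on an amide-type nitrogen. Among the compounds with values here, two measured steps bear on this change, since both replace an aryl group on the amide nitrogen with the 4-methylbenzyl group: a 4.3-fold lower number from compound 1 to compound 3 (0.63 log units; beyond the scatter) and a 2.8-fold lower number from compound 2 to compound 3 (0.45 log units; beyond the scatter). Compound 4 reverses that direction, bringing back an aryl group directly on the amide nitrogen, and the closest measured analogue is compound 1, which carries a chlorophenyl group of a different substitution pattern. On that basis a modest rise in this assay is expected from compound 3 to compound 4, roughly the size of a 4.3-fold lower number from compound 1 to compound 3 (0.63 log units; beyond the scatter) reversed, giving an expected step of a 3.5-fold higher number from compound 3 to compound 4 (0.54 log units; beyond the scatter). The estimate for compound 4 in this assay is therefore 900000 nM, with a range from 400000 nM to 2000000 nM.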

Compound 4, half-maximal cytotoxic concentration: 272000 nM
For compound 4 the middle estimate is 3.3-fold (0.52 log units) above the measured one; measured number below the stated range.
By their numbers in this assay, from the lowest: compounds 3 and 4 (each within the scatter of the next); then compounds 2 and 1 (each within the scatter of the next).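

In this assay, the step of a 1.1-fold higher number from compound 3 to compound 4 (0.02 log units; within the scatter) shows that an aryl group directly on the amide-type nitrogen does not by itself set a compound apart from the 4-methylbenzyl compound, as the earlier aryl amides alone might have suggested. The chlorine's ring position counts, since moving from 3-chlorophenyl to 4-chlorophenyl gives a 4.0-fold lower number from compound 1 to compound 4 (0.61 log units; beyond the scatter), a step beyond the scatter. The 4-substituent counts as well, since chloro in place of methoxy on an aromatic carbon gives a 2.6-fold lower number from compound 2 to compound 4 (0.42 log units; beyond the scatter), which places compound 4 with compound 3 at the low end of the four numbers, apart from compound 1 and compound 2.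

No evidence beyond these numbers bears on why the steps take the sizes they do. Still open, on these data alone, is whether a 4-chlorobenzyl group on the same nitrogen would stay level with compound 3 and compound 4, and whether an amine or a carboxylic acid on the phenyl ring would fall with the chloro compound or with the methoxy compound.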